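Clearance notes: from compound 2 to compound 4

This account rests on a few compounds, and the source may have more. Where it says the series, first, only, none or still open, it means among the compounds named here.

Values in an ADME assay on microsomes from liver (Homo sapiens) for metabolic stability (on this read-out lower numbers stand for slow clearance and higher numbers for fast clearance), for the series:
- compound 1 (`CC(NC(=O)Cn1nnc2ccccc2c1=O)c1ccc(Cl)cc1`) gives < 9.9 mL/min/kg as a limit
- compound 2 (`Cc1cccc([C@H](C)NC(=O)Cn2nnc3ccccc3c2=O)c1`) gives 11 mL/min/kg
- compound 3 (`C[C@@H](NC(=O)Cn1nnc2ccccc2c1=O)c1ccccc1`) gives < 9.9 mL/min/kg as a limit

Within the data shown here, compound 2 at 11 mL/min/kg carries the only true number in the set. What remains is the limit of < 9.9 mL/min/kg in this assay, at which 2 of the 3 values shown sit, and those entries are limits rather than numbers. No order among the three can be read from this.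

Compound 4 (`COc1ccc([C@H](C)NC(=O)Cn2nnc3ccccc3c2=O)cc1`) has not yet been measured. Its change from compound 2 is 4-methoxyphenyl in place of 3-methylphenyl on a saturated chain carbon bound to an amide-type nitrogen and a saturated chain carbon and it puts 4-methoxyphenyl in place of 3-methylphenyl on a saturated chain carbon bound to an amide-type nitrogen and a saturated chain carbon.

Among the measured compounds shown here, the set holds no measured step at a single place to scale from. For the measured compounds named here, the expectation therefore rests on compound 2 at 11 mL/min/kg as the one number available. The step expected in this assay is none beyond the scatter in either direction, and the estimated 1.1-fold higher number from compound 2 to compound 4 (0.04 log units; within the scatter) stays inside it. A report of only a limit would also fit this expectation. For compound 4 the expected clearance is 12 mL/min/kg within an estimated range of 7 mL/min/kg to 25 mL/min/kg on this read-out.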

Compound 4, clearance: 13 mL/min/kg
For compound 4 the middle estimate is 1.1-fold (0.03 log units) below the measured one; measured number inside the range.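

In this assay, among these compounds, replacing 3-methylphenyl with 4-methoxyphenyl on a saturated chain carbon bound to an amide-type nitrogen and a saturated chain carbon gives a 1.2-fold higher number from compound 2 to compound 4 (0.07 log units; within the scatter), the first measured step at a single place. This position therefore accepts the exchange with no readable change in clearance, even though the entering group adds an oxygen and a hydrogen-bond acceptor that the leaving group lacks. The series now holds two true numbers, but neither can be ordered against the remaining entries because those entries are limits and not numbers: the limit of < 9.9 mL/min/kg in this assay, at which 2 of the 4 values shown sit.

The step alters the substituent and its place on the phenyl ring together, and without 4-methylphenyl or 3-methoxyphenyl in this assay these two changes cannot be told apart. Also open, as far as these compounds go, is whether the tolerance seen here extends beyond small neutral substituents, for example to a phenyl ring carrying an amine or a carboxylic acid, or to a pyridine ring in place of the phenyl ring.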